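This account rests on a few compounds, and the source may have more. Where it says the series, first, only, none or still open, it means among the compounds named here.

Compounds measured in a functional assay on RAW264.7 cells (Mus musculus) for inhibition, read by Griess assay, with stated times of 2 h and 24 h; a higher number here means a weaker inhibitor, a lower number a stronger inhibitor:

compound 1 `COc1ccc([C@@H]2CC(=O)c3c(O)cc(OCc4cn(Cc5ccccc5F)nn4)cc3O2)cc1O`: 7320 nM
compound 2 `COc1ccc([C@@H]2CC(=O)c3c(O)cc(OCc4cn(Cc5ccc(Cl)cc5)nn4)cc3O2)cc1O`: 17800 nM
compound 3 `CCn1cc(COc2cc(O)c3c(c2)O[C@H](c2ccc(OC)c(O)c2)CC3=O)nn1`: 15000 nM

Compound 3 stands second highest of the three numbers. Its nearest neighbour is compound 2, the step being a 1.2-fold lower number from compound 2 to compound 3 (0.07 log units; within the scatter), and its furthest is compound 1, with a 2.0-fold higher number from compound 1 to compound 3 (0.31 log units; beyond the scatter). For the measured compounds named here, the one step not involving compound 3, a 2.4-fold higher number from compound 1 to compound 2 (0.39 log units; beyond the scatter), is modest as well.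

Compound 4 `COc1ccc([C@@H]2CC(=O)c3c(O)cc(OCc4cn(Cc5ccc(C)cc5)nn4)cc3O2)cc1O` differs from compound 3 by 4-methylphenyl in place of methyl on a saturated chain carbon bound to an aromatic nitrogen. Both steps into compound 3 bear on this change, since each exchanges a substituted phenyl for methyl on the same saturated chain carbon bound to an aromatic nitrogen. The 4-chlorophenyl case gave a step within the scatter, the 2-fluorophenyl case a modest step beyond it. A 4-methylphenyl entering in place of methyl is therefore expected to give at most a small step in this assay, likely none beyond the scatter, with the estimated change being a 1.1-fold lower number from compound 3 to compound 4 (0.03 log units; within the scatter). Compound 4 is estimated at 14000 nM, within 6000 nM to 32000 nM.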

Compound 4, half-maximal inhibitory concentration: 16800 nM
For compound 4 the middle estimate is 1.2-fold (0.08 log units) below the measured one; measured number inside the range.
By their numbers in this assay, from the lowest: compound 1; then compounds 3, 4 and 2 (each within the scatter of the next).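

In this assay, 4-methylphenyl in place of methyl on the saturated chain carbon bound to an aromatic nitrogen gives a 1.1-fold higher number from compound 3 to compound 4 (0.05 log units; within the scatter) and so joins the 4-chlorophenyl case in not being told apart from methyl. Methyl in place of chloro on an aromatic carbon gives a 1.1-fold lower number from compound 2 to compound 4 (0.03 log units; within the scatter), the first step in the series made on the phenyl ring itself, and a 2.3-fold higher number from compound 1 to compound 4 (0.36 log units; beyond the scatter) leaves compound 1, carrying 2-fluorophenyl, as the only compound with steps beyond the scatter to all three others. No measurement on hand offers an explanation for this separation.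

Still open, as far as these compounds go, is whether a 4-fluorophenyl would read with compound 1 or with compounds 2, 3 and 4. An amine or a carboxylic acid on the phenyl ring, or a longer chain in place of methyl, also remains to be placed against these numbers.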